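Sulfonamide series: aryl change from compound 1 to compound 3

The source may hold more compounds than are shown below. What is called first, only, known or untested is meant among the compounds shown, and "the series" means these compounds.

Measured so far:
compound 1 `CC1CCN(C2CCN(S(=O)(=O)c3ccccc3Br)CC2)CC1`, 3 nM
compound 2 `CC1CCN(C2CCN(S(=O)(=O)c3ccccc3-c3ccc(C(F)(F)F)cc3)CC2)CC1`, 122 nM

In a functional assay on DLD-1 cells (Homo sapiens) for antiproliferative activity, read by CellTiter-Glo, with a stated time of 72 h (on this read-out higher numbers stand for weaker inhibition and lower numbers for stronger inhibition), compound 1 gives 3 nM, the lower of the two values measured, while compound 2 gives 122 nM. Among the compounds with values here, the single measured step, a 41-fold higher number from compound 1 to compound 2 (1.61 log units; beyond the scatter), shows that altering the aryl ring on the sulfonyl sulfur can cost a great deal. Compound 3 `COc1cccc(S(=O)(=O)N2CCC(N3CCC(C)CC3)CC2)c1` differs from compound 1 at the same place but in another way: 3-methoxyphenyl in place of 2-bromophenyl on a sulfonyl sulfur. Within the data shown here, both the bromine and its position on the ring are given up for a methoxy group, so this step is not the same as the one to compound 2 and can be read from it only loosely. Some loss against compound 1 is expected, smaller than that to compound 2, because a 41-fold higher number from compound 1 to compound 2 (1.61 log units; beyond the scatter) involved 4-(trifluoromethyl)phenyl in place of bromo rather than a single small group. For compound 3 the expected value in this assay is 20 nM, within 4 nM to 120 nM, an estimated step of a 6.7-fold higher number from compound 1 to compound 3 (0.82 log units; beyond the scatter).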

Compound 3, half-maximal inhibitory concentration: > 5000 nM
Compound 3 gave a limit, no number (the forecaster's own chance of this, stated with the estimate: 5%); at least 250-fold (2.39 log units) between middle value and limit.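

In this assay compound 3 gives > 5000 nM, which is a limit of the assay and not a number. Within the data shown here, the exchange at the sulfonyl sulfur is modest by count, with 7 heavy atoms leaving and 8 entering, yet the step is an at least 1600-fold higher number from compound 1 to compound 3 (3.22 log units; beyond the scatter), so a large loss at this place does not require an added aryl ring like the one in compound 2. The true size of this step stays unknown, and only its lower bound can be read: the limit of > 5000 nM in this assay, at which 1 of the 3 values shown sits.

From the compounds shown here alone, whether the loss follows from giving up the bromine or from the place of the methoxy group on the ring stays open, since 2-bromophenyl and 3-methoxyphenyl differ in both. Also open, going by these compounds, is how a chlorine, a nitrile or an amine on the ring would behave in place of the bromo group.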